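Working notes: trifluoromethyl in place of fluoro

The source may report more compounds than this note shows. Statements on the series, on what has been measured and on what is new or still open speak of the compounds shown alone.

The three compounds share one core and differ only at one aromatic carbon of a six-membered aromatic ring of carbon only. Two have been measured: compound 1 `CCOC(=O)CCCCCOc1cccc(CN(C(=O)c2ccc(-c3cc(C(F)(F)F)cc(C(F)(F)F)c3)cc2)C(C)C)c1` and compound 2 `CCOC(=O)CCCCCOc1cccc(CN(C(=O)c2ccc(-c3cccc(F)c3)cc2)C(C)C)c1`. In an ADME assay on HepG2 cells (Homo sapiens) for cytotoxicity, read by CellTiter-Glo and resazurin assay, with a stated time of 72 h (a lower number here means that less compound is needed, a higher number that more compound is needed for the effect), compound 1 gives > 26000 nM, which is a limit of the assay and not a number. In this assay compound 2 gives > 26000 nM, again a limit rather than a measured number. Compound 2 therefore stands at the limit of > 26000 nM in this assay, at which 2 of the 2 values shown sit, without a numerical value of its own. Among the compounds with values here, no step between two measured compounds can be drawn, since compound 1 and compound 2 differ in more than one place.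

The unmeasured compound 3 `CCOC(=O)CCCCCOc1cccc(CN(C(=O)c2ccc(-c3cccc(C(F)(F)F)c3)cc2)C(C)C)c1` differs from compound 2 by trifluoromethyl in place of fluoro on an aromatic carbon; cut one bond further out, the change reads 3-fluorophenyl to 3-(trifluoromethyl)phenyl. With both measured values sitting at the limit, no step beyond the scatter is expected in this assay. The step expected from a step that the limit leaves unreadable from compound 2 to compound 3 is accordingly small, in no particular direction. Compound 3 is estimated at about 40000 nM, within 15000 nM to 120000 nM, and this assay is expected most likely to report only its limit again.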

Compound 3, half-maximal effective concentration: > 26000 nM
Compound 3 gave a limit, no number; the forecaster's own chance of this, stated with the estimate: 80%; the middle value is on the limit's open side.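

In this assay compound 3 gives > 26000 nM, a limit of the assay and not a number. No step from compound 3 to compound 1 or compound 2 can be read, because all three compounds sit at the same limit: the limit of > 26000 nM in this assay, at which 3 of the 3 values shown sit.

The compounds shown leave open whether the change on the aromatic ring alters the read-out at all.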